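A few compounds are considered here, and "the series" means these few. Any claim that something is new, unique, unknown or untested is made for them only; others in the source may bear on it.

Measured so far:
Compound 1, `CCO[C@]1(c2ccc(OCc3c(-c4c(Cl)cccc4Cl)noc3C3CC3)cc2Cl)C[C@H](c2cccc(C(=O)O)c2)C1`: 220 nM
Compound 2, `O=C(O)c1cccc([C@H]2C[C@](O)(c3ccc(OCc4c(-c5c(Cl)cccc5Cl)noc4C4CC4)cc3Cl)C2)c1`: 25 nM

In an assay on HEK293 cells for agonist activity at Bile acid receptor (Homo sapiens) (on this read-out higher numbers stand for an effect only at larger amounts of compound and lower numbers for an effect already at smaller amounts), compound 2 holds the lower of the two numbers. Within the data shown here, the only measured step, an 8.8-fold lower number from compound 1 to compound 2 (0.94 log units; beyond the scatter), came from hydrogen in place of ethyl on an oxygen on a saturated carbon. Compound 3, `O=C(O)c1cccc([C@H]2C[C@](OCCO)(c3ccc(OCc4c(-c5c(Cl)cccc5Cl)noc4C4CC4)cc3Cl)C2)c1`, goes the other way at that oxygen: 2-hydroxyethyl in place of hydrogen on an oxygen on a saturated carbon. Because that measured step an 8.8-fold lower number from compound 1 to compound 2 (0.94 log units; beyond the scatter) lowered the number when the oxygen was freed, capping it again is expected to raise the number, though the entering group is not ethyl, so a smaller step is expected. Compound 3 is expected to show a 3.2-fold higher number from compound 2 to compound 3 (0.51 log units; beyond the scatter). The estimate for compound 3 is 80 nM, between 30 nM and 250 nM.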

Compound 3, half-maximal effective concentration: 377 nM
Compound 3: the middle estimate sits 4.7-fold (0.67 log units) below what was measured; the measured number lies above the stated range.
By their numbers in this assay, from the lowest: compound 2; then compounds 1 and 3 (each within the scatter of the next).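

In this assay the oxygen tolerates a cap poorly even when the cap carries its own hydroxy: 2-hydroxyethyl in place of hydrogen gives a 15-fold higher number from compound 2 to compound 3 (1.18 log units; beyond the scatter) and so ends up on the same side as ethyl. Adding the hydroxy to the ethyl chain gives a 1.7-fold higher number from compound 1 to compound 3 (0.23 log units; within the scatter) and so no readable difference, which means the free hydroxy on the ring carbon is not matched by one further out on a chain. Nothing measured here gives a reason for this. Still open, as far as these compounds go, is how a smaller methyl cap would compare at this oxygen, or a chain ending in an amine or a carboxylic acid.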